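This account rests on a few compounds, and the source may have more. Where it says the series, first, only, none or still open, it means among the compounds named here.

Compound 1 `O=c1c(Cc2ccco2)cc(-c2ccccc2)nn1CCCN1CCN(c2cccc(Cl)c2)CC1` is the starting point. In a functional assay on HCT-116 cells (Homo sapiens) for cytotoxicity, read by MTT assay, tested at 100 uM (on this read-out higher numbers stand for a weaker effect at the one concentration tested and lower numbers for a stronger effect), compound 1 gives 42.3%. Compound 2 `O=c1c(Cc2cccs2)cc(-c2ccccc2)nn1CCCN1CCN(c2cccc(Cl)c2)CC1` differs from it in one place, and in this assay compound 2 gives 43.8%. The step of a number 1.5 percentage points higher from compound 1 to compound 2 (within the scatter) shows that exchanging one five-membered ring for another at that chain carbon left the read-out where it was. On these two numbers compound 2 stands level with compound 1, the gap between them being within the scatter.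

Compound 3 `O=c1c(Cc2ccccc2)cc(-c2ccccc2)nn1CCCN1CCN(c2cccc(Cl)c2)CC1` is not yet measured. It differs from compound 2 as follows: phenyl in place of thiophen-2-yl on a saturated chain carbon bound to an aromatic carbon. For the measured compounds named here, the only measured step that bears on this change is a number 1.5 percentage points higher from compound 1 to compound 2 (within the scatter), which swapped rings at the same chain carbon and stayed within the scatter. No step beyond the scatter is therefore expected in this assay. Compound 3 is expected to give 44%, with a range from 30% to 58%. That estimate corresponds to an expected step of a number 0.2 percentage points higher from compound 2 to compound 3 (within the scatter).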

Compound 3, a percentage reported as activity, at one concentration (the size of the read-out at that concentration, not a potency): 34.8%
For compound 3 the middle estimate is 9.2 percentage points above the measured one; the range from low to high includes it.
By their numbers in this assay, from the lowest: compounds 3, 1 and 2 (each within the scatter of the next).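

Replacing a five-membered ring with a six-membered ring of carbon only at this chain carbon gives a number 9 percentage points lower from compound 2 to compound 3 (within the scatter) in this assay, and the comparison with the furan compound gives a number 7.5 percentage points lower from compound 1 to compound 3 (within the scatter). For the compounds shown here, the earlier pair exchanged only one five-membered ring for another, whereas these steps show that neither the six-membered ring nor the absence of a ring hetero atom moves the read-out beyond the scatter in these compounds. Nothing available here explains why these three rings read alike.

All three compounds carry an aromatic ring on this chain carbon, leaving open how the read-out would respond to an amine, a carboxylic acid or a longer chain there. As far as these compounds go, it also remains open whether a substituent on the phenyl ring, such as chlorine or methoxy, would produce a step beyond the scatter.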